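Same atoms, rearranged chain: from compound 2 to compound 3

This account rests on a few compounds, and the source may have more. Where it says the series, first, only, none or still open, it means among the compounds named here.

compound 1 `COc1cc2ncnc(-n3nc(-c4ccccn4)nc3N)c2cc1OCc1ccccc1` (58000 nM)
compound 2 `COc1cc2ncnc(-n3nc(-c4ccccn4)nc3N)c2cc1OCCNC(=O)OC(C)(C)C` (2000 nM)

Both numbers come from a physicochemical assay for solubility, in phosphate buffer, with a stated time of 18 h, at pH 7.4 (on this read-out lower numbers stand for lower solubility and higher numbers for higher solubility), and compound 2 holds the lower of the two. The next compound to be measured is compound 3 `COc1cc2ncnc(-n3nc(-c4ccccn4)nc3N)c2cc1OCCCNC(=O)OC(C)C` and its difference from compound 2 counts up as ((isopropoxycarbonyl)amino)methyl in place of (tert-butoxycarbonyl)amino on a saturated chain carbon, two bonds along the chain from an oxygen on an aromatic ring in the side chain. In words, ((isopropoxycarbonyl)amino)methyl stands in place of (tert-butoxycarbonyl)amino on a saturated chain carbon, two bonds along the chain from an oxygen on an aromatic ring. The two compounds have the same atoms, joined differently.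

For the measured compounds named here, the only measured step is a 29-fold lower number from compound 1 to compound 2 (1.46 log units; beyond the scatter) and it is large. That step put ((tert-butoxycarbonyl)amino)methyl in place of phenyl, a different kind of change, so it gives no direct measure here. Going by the values given here, no measured pair shows a same-atom rearrangement. A step within the scatter is therefore expected, with no firm direction, and the estimate starts from compound 2 at 2000 nM as its anchor. The expected step is a 1.3-fold higher number from compound 2 to compound 3 (0.10 log units; within the scatter) in this assay overall. For compound 3 the estimated value is 2500 nM with an expected range from 800 nM to 8000 nM as its limits.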

Compound 3, solubility: 18000 nM
Beside the measured number, compound 3's estimate is 7.2-fold (0.86 log units) below it, outside the stated range (above it).
By their numbers in this assay, from the lowest: compound 2; then compound 3; then compound 1.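

Replacing 2-((tert-butoxycarbonyl)amino)ethoxy with 3-((isopropoxycarbonyl)amino)propoxy leaves the atom count unchanged, yet in this assay the change gives a 9.0-fold higher number from compound 2 to compound 3 (0.95 log units; beyond the scatter), so at this place, on a saturated chain carbon, two bonds along the chain from an oxygen on an aromatic ring, how the same atoms are joined can move the read-out clearly. Measured against the phenyl-bearing compound, 2-((isopropoxycarbonyl)amino)ethyl in place of phenyl gives a 3.2-fold lower number from compound 1 to compound 3 (0.51 log units; beyond the scatter), a smaller gap than a 29-fold lower number from compound 1 to compound 2 (1.46 log units; beyond the scatter), so a side chain of this kind need not cost as much on this read-out as compound 2 suggested. Nothing measured here explains why these steps have the size they do.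

This one step changes two things together, the length of the chain and tert-butyl giving way to isopropyl, and the compounds shown cannot separate the two, as neither the isopropyl group on the shorter chain nor the tert-butyl group on the longer chain appears among them. Also open, as far as these compounds go, is how the read-out would respond to a plain amine or a carboxylic acid in place of the (isopropoxycarbonyl)amino group.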